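A Second Methoxy Group on a Pair with Low Numbers

This account rests on a few compounds, and the source may have more. Where it says the series, first, only, none or still open, it means among the compounds named here.

compound 1 `COc1ccc([C@]2(CO)NC[C@@H](O)[C@@H]2O)cc1`: 2.7%
compound 2 `COc1cccc([C@]2(CO)NC[C@@H](O)[C@@H]2O)c1`: 0%

Of the compounds shown here, two have been tested in an assay on isolated protein for inhibition of tissue alpha-L-fucosidase (Bos taurus), tested at 1000 uM; a higher number here means more inhibition at the concentration tested (going by the name of the read-out), a lower number less inhibition. In this assay compound 1 gives 2.7%, while compound 2 gives 0%. Compound 2 stands lowest of the two numbers, but its nearest neighbour, compound 1, lies within the scatter of it, so the two cannot be told apart on these figures; both sit at the floor of the read-out.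

Compound 3 `COc1ccc([C@]2(CO)NC[C@@H](O)[C@@H]2O)cc1OC` has not been measured. It differs from compound 2 by methoxy in place of hydrogen on an aromatic carbon. Among the compounds with values here, no pair of measured compounds differing in one place exists here, so no step has been observed. Since compound 1 and compound 2 both give essentially no inhibition in this assay, compound 3 is expected to show a step of a number 3 percentage points higher from compound 2 to compound 3 (within the scatter), not beyond the scatter. Compound 3 is estimated at 3%, within a range of 0% to 13%.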

Compound 3, a percentage reported as inhibition, at one concentration (the size of the read-out at that concentration, not a potency): 0%
Estimate against measurement, compound 3: 3 percentage points above; the measured number falls inside the stated range.
By their numbers in this assay, from the lowest: compounds 2, 3 and 1 (each within the scatter of the next).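

In this assay, the methoxy group that enters ortho to a methoxy group and para to a group of 9 heavy atoms gives no change at the digits printed from compound 2 to compound 3 (within the scatter), and the same kind of change read from the other side gives a number 2.7 percentage points lower from compound 1 to compound 3 (within the scatter). Within the data shown here, these are the first one-place steps, and neither lifts the number out of the scatter, so a second methoxy group on the aromatic ring brings no detectable inhibition to either parent at this high test concentration. Nothing available explains why the three compounds stay at the floor of the read-out.

With all three at that floor, any smaller influence of the methoxy group stays hidden. As far as these compounds go, whether an amine, a carboxylic acid or a longer chain at this position would give a measurable number remains open.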